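Fluoro to Chloro Swap Carried onto an Acid Analogue

The compounds below may be only part of what the source reports. "The series", "measured", "known", "first", "only" and "open" are said of these compounds alone.

Compound 1 `COC(=O)C(Nc1cc(CS(=O)(=O)/C=C/c2c(OC)cc(OC)cc2OC)ccc1OC)c1ccc(F)cc1` and compound 2 `COC(=O)C(Nc1cc(CS(=O)(=O)/C=C/c2c(OC)cc(OC)cc2OC)ccc1OC)c1ccc(Cl)cc1` share one core and differ only in chloro in place of fluoro on an aromatic carbon. In a functional assay on DU-145 cells (Homo sapiens) for cytotoxicity, read by trypan blue exclusion, with a stated time of 96 h (on this read-out lower numbers stand for stronger inhibition and higher numbers for weaker inhibition), compound 1 gives 300 nM, and compound 2 gives 400 nM; the step between them is a 1.3-fold higher number from compound 1 to compound 2 (0.12 log units; within the scatter). Compound 3 `COc1cc(OC)c(/C=C/S(=O)(=O)Cc2ccc(OC)c(NC(C(=O)O)c3ccc(F)cc3)c2)c(OC)c1` keeps the core of compound 1 but differs from it in hydrogen in place of methyl on an oxygen next to a carbonyl group. In this assay compound 3 gives 150 nM, which is a 2.0-fold lower number from compound 1 to compound 3 (0.30 log units; within the scatter) and, set against compound 2, a 2.7-fold lower number from compound 2 to compound 3 (0.43 log units; beyond the scatter). Compound 4 `COc1cc(OC)c(/C=C/S(=O)(=O)Cc2ccc(OC)c(NC(C(=O)O)c3ccc(Cl)cc3)c2)c(OC)c1` has not yet been measured in this assay. It differs from compound 3 in chloro in place of fluoro on an aromatic carbon, which is the same change as that made from compound 1 to compound 2, sitting in the same place on both cores. Because the earlier step of a 1.3-fold higher number from compound 1 to compound 2 (0.12 log units; within the scatter) stayed within the scatter, the account expects a step of similar size, a 1.3-fold higher number from compound 3 to compound 4 (0.12 log units; within the scatter), on the acid core as well. Compound 4 is therefore estimated at 200 nM in this assay, expected to fall between 100 nM and 400 nM.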

Compound 4, half-maximal inhibitory concentration: 400 nM
Estimate against measurement, compound 4: 2.0-fold (0.30 log units) below, and the stated range covers the measured number.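

In this assay, chloro in place of fluoro on the core of compound 3 gives a 2.7-fold higher number from compound 3 to compound 4 (0.43 log units; beyond the scatter), a larger step on its face than the one on the core of compound 1, yet the two cannot be told apart: the same change on two cores in this assay, a 1.3-fold higher number (0.12 log units; within the scatter) from compound 1 to compound 2 and a 2.7-fold higher number (0.43 log units; beyond the scatter) from compound 3 to compound 4, 2.0-fold (0.30 log units) apart, within the scatter of two such steps. The other change in the set, hydrogen in place of methyl, gives no change at the digits printed from compound 2 to compound 4 (within the scatter), and this too cannot be separated from its earlier counterpart: the same change on two cores in this assay, a 2.0-fold lower number (0.30 log units; within the scatter) from compound 1 to compound 3 and no change at the digits printed (within the scatter) from compound 2 to compound 4, 2.0-fold (0.30 log units) apart, within the scatter of two such steps. Both changes therefore carried from one core to the other without a difference beyond the scatter, but this does not show that the steps are equal, and a 1.3-fold higher number from compound 1 to compound 4 (0.12 log units; within the scatter) combines the two changes, so it says nothing about either alone.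

The compounds shown leave open whether the same holds when bromo or methyl stands in place of fluoro on the aromatic carbon. They also leave open whether it holds when an amide or a primary alcohol replaces the carboxy group.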